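A Hydroxyl Shift on the Piperidine of Compound 4

A few compounds are considered here, and "the series" means these few. Any claim that something is new, unique, unknown or untested is made for them only; others in the source may bear on it.

Compound 2 `CC(=O)N1CCN(C2CN(CCC3(c4ccc(Cl)c(Cl)c4)CCC(=O)N(Cc4ccccc4)C3)C2)CC1` gives 1.59 nM in an assay on isolated protein (artery, Oryctolagus cuniculus) with Substance-P receptor (Homo sapiens) as the target (on this read-out higher numbers stand for weaker binding and lower numbers for tighter binding), the second highest of the three measured values. Compound 1 `O=C1CCC(CCN2CC(N3CCOCC3=O)C2)(c2ccc(Cl)c(Cl)c2)CN1Cc1ccccc1` gives 2.51 nM in this assay, and the step of a 1.6-fold lower number from compound 1 to compound 2 (0.20 log units; within the scatter) stays within the scatter. Compound 3 `O=C1CCC(CCN2CC(N3CCC(O)CC3)C2)(c2ccc(Cl)c(Cl)c2)CN1Cc1ccccc1` gives 0.0794 nM; the steps of a 32-fold lower number from compound 1 to compound 3 (1.50 log units; beyond the scatter) and a 20-fold lower number from compound 2 to compound 3 (1.30 log units; beyond the scatter) are both large. Compound 4 `O=C1CCC(CCN2CC(N3CCCC(O)C3)C2)(c2ccc(Cl)c(Cl)c2)CN1Cc1ccccc1` differs from compound 2 by 3-hydroxypiperidin-1-yl in place of 4-acetylpiperazin-1-yl on a saturated ring carbon. Because the step of a 20-fold lower number from compound 2 to compound 3 (1.30 log units; beyond the scatter) likewise brings in a hydroxypiperidine in place of the 4-acetylpiperazin-1-yl group, a large move toward tighter binding is expected in this assay, an 8.0-fold lower number from compound 2 to compound 4 (0.90 log units; beyond the scatter). Compound 4 is thus expected to give about 0.2 nM, with a range from 0.04 nM to 1 nM.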

Compound 4, dissociation constant: 2 nM
The estimate for compound 4 lay 10-fold (1.00 log units) below the measured number; measured number outside the range, above it.
By their numbers in this assay, from the lowest: compound 3; then compounds 2, 4 and 1 (each within the scatter of the next).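

In this assay, the place of the hydroxyl on the piperidine matters at this position: a 25-fold higher number from compound 3 to compound 4 (1.40 log units; beyond the scatter) shows that a hydroxypiperidine alone does not bring the tight binding of compound 3. With a 1.3-fold higher number from compound 2 to compound 4 (0.10 log units; within the scatter) and a 1.3-fold lower number from compound 1 to compound 4 (0.10 log units; within the scatter) within the scatter, the 3-hydroxypiperidin-1-yl group stays level with both the 4-acetylpiperazin-1-yl and 3-oxomorpholin-4-yl groups. Nothing available explains this gap between the two hydroxypiperidines. The compounds shown leave open whether an amine in place of the hydroxyl of compound 3 would keep binding this tight.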